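The source may report more compounds than this note shows. Statements on the series, on what has been measured and on what is new or still open speak of the compounds shown alone.

Measured compounds in an assay on isolated protein for inhibition of thyroid hormone receptor alpha (Homo sapiens), read by fluorescence polarization; on this read-out higher numbers stand for weaker inhibition and lower numbers for stronger inhibition:
compound 1 `CS(=O)(=O)c1ccc(C(=O)NCCC(=O)N2CCCc3ccccc32)cc1[N+](=O)[O-]` gives > 60000 nM
compound 2 `CS(=O)(=O)c1ccc(C(=O)N2CCC(C(=O)N3CCC(c4ccccc4)CC3)CC2)cc1[N+](=O)[O-]` gives > 60000 nM
compound 3 `CS(=O)(=O)c1ccc(C(=O)NCC(=O)N2CCCCC2)cc1[N+](=O)[O-]` gives 44000 nM

The values of compound 1 and compound 2 are limits of the assay, not numbers. Compound 1 in this assay gives > 60000 nM, which is a limit. Compound 2 gives > 60000 nM, likewise a limit. Only compound 3 yields an actual number, 44000 nM, and that number sits close to the limit of > 60000 nM in this assay, at which 2 of the 3 values shown sit. Compound 1 therefore stands at the weak end of what this assay can report. For the measured compounds named here, no step between measured compounds that differ in one place is available, so no measured size of change exists to lean on.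

Compound 4 `CC1CCN(C(=O)CCNC(=O)c2ccc(S(C)(=O)=O)c([N+](=O)[O-])c2)CC1` is not yet measured. It differs from compound 1 in one place: 4-methylpiperidin-1-yl in place of 1,2,3,4-tetrahydroquinolin-1-yl on a carbonyl carbon. Nothing among compounds 1, 2 and 3 points to measurable inhibition arising from a change of this kind at that carbonyl carbon; all three sit at or near the limit. Compound 4 is therefore expected to remain near the limit. The step of a number no higher from compound 1 to compound 4 (the limit leaves the size open) is expected to lie within the scatter, if a number is obtained at all. The estimate for compound 4 is 60000 nM, expected to fall between 30000 nM and 120000 nM.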

Compound 4, half-maximal inhibitory concentration: > 60000 nM
Compound 4: a limit, no number; the forecaster's own chance of this, stated with the estimate: 60%; the middle value lies on the limit itself.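

In this assay compound 4 gives > 60000 nM, a limit and not a number. Compound 1 also stands at a limit, so no step can be read between compound 1 and compound 4. The compounds shown leave open whether 4-methylpiperidin-1-yl and 1,2,3,4-tetrahydroquinolin-1-yl on that carbonyl carbon differ in inhibition at all: the limit of > 60000 nM in this assay, at which 3 of the 4 values shown sit.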